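A Nitro Group Added to a Longer-Chain Analogue

The compounds below may be only part of what the source reports. "The series", "measured", "known", "first", "only" and "open" are said of these compounds alone.

This set concerns four compounds built on closely related cores and tested in a functional assay on SH-SY5Y cells (Homo sapiens) for antiproliferative activity, read by MTT assay, with a stated time of 72 h; a lower number here means a stronger inhibitor, a higher number a weaker inhibitor. Compound 2 `c1ccc(COc2ccc(Nc3ncnc4cc5c(cc34)OCCOCCO5)cc2)cc1` gives 39300 nM in this assay. Compound 1 `O=[N+]([O-])c1ccc(COc2ccc(Nc3ncnc4cc5c(cc34)OCCOCCO5)cc2)cc1` differs from it by nitro in place of hydrogen on an aromatic carbon and gives 55200 nM; the step of a 1.4-fold higher number from compound 2 to compound 1 (0.15 log units; within the scatter) is thus small. Compound 3 `c1ccc(COc2cccc(Nc3ncnc4cc5c(cc34)OCCOCCOCCO5)c2)cc1` carries a different core, and how its core differs from that of compound 2 is not broken down here. In this assay compound 3 gives 22800 nM; its gap to compound 2 lies within the scatter, while its gap to compound 1 lies beyond it. Compound 4 `O=[N+]([O-])c1ccc(COc2cccc(Nc3ncnc4cc5c(cc34)OCCOCCOCCO5)c2)cc1` has not yet been measured. It differs from compound 3 by nitro in place of hydrogen on an aromatic carbon, the same change that turned compound 2 into compound 1, made at a place described in identical words. The expected step of a 1.3-fold higher number from compound 3 to compound 4 (0.12 log units; within the scatter) rests on the earlier step of a 1.4-fold higher number from compound 2 to compound 1 (0.15 log units; within the scatter), which stayed within the scatter. For compound 4 the estimate is 30000 nM, with a range from 15000 nM to 60000 nM.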

Compound 4, half-maximal inhibitory concentration: > 100000 nM
Compound 4 was reported as a limit; the forecaster's own chance of this, stated with the estimate: 10%; at least 3.3-fold (0.52 log units) between middle value and limit.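

In this assay compound 4 gives > 100000 nM, which is a limit of the assay and not a number. Putting a nitro group in place of hydrogen gives an at least 4.3-fold higher number from compound 3 to compound 4 (0.64 log units; beyond the scatter), so on this core the change does not stay as small as it did on the other core: the same change on two cores in this assay, a 1.4-fold higher number (0.15 log units; within the scatter) from compound 2 to compound 1 and an at least 4.3-fold higher number (0.64 log units; beyond the scatter) from compound 3 to compound 4, at least 3.1-fold (0.49 log units) apart, beyond the scatter of two such steps. On these data alone, this shows that the size of the step did not carry over from one core to the other, but it does not show which feature of the cores matters, and the full size of the new step stays unknown, since the value is only a limit: the limit of > 100000 nM in this assay, at which 1 of the 4 values shown sits.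

The compounds shown leave open whether the larger step is tied to the nitro group itself, which an amine or a nitrile in its place on each core could test. They also leave open which part of the core goes with the larger step, which a pair of cores differing in one place only, such as a longer chain, could separate.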